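This account rests on a few compounds, and the source may have more. Where it says the series, first, only, none or still open, it means among the compounds named here.

Working notes on the series in an assay on CHO cells for displacement of a labelled ligand from Substance-P receptor (Homo sapiens); on this read-out lower numbers stand for stronger inhibition and higher numbers for weaker inhibition.

Of the compounds shown here, three have numbers so far. Compound 1 `C[C@@H](O[C@H]1CN2C(=O)NC[C@H]2[C@@H]1c1ccc(F)cc1)c1cc(C(F)(F)F)cc(C(F)(F)F)c1` gives 0.06 nM in this assay. Compound 2 `C[C@@H](O[C@@H]1[C@@H](c2ccccc2)CN2C(=O)OC[C@H]12)c1cc(C(F)(F)F)cc(C(F)(F)F)c1` gives 1.5 nM in this assay. Compound 3 `C[C@@H](O[C@H]1CN(C(=O)OC(C)(C)C)[C@@H](CO)[C@@H]1c1ccccc1)c1cc(C(F)(F)F)cc(C(F)(F)F)c1` gives 0.63 nM in this assay. Compound 1 thus stands at the lowest number of the three; the nearest, compound 3, sits beyond the scatter, and compound 2 sits further still, also beyond the scatter. Compound 2 and compound 3 differ from compound 1 in several places at once, so no single structural step can be read from their numbers.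

Compound 4 `C[C@@H](O[C@H]1CN2C(=O)N(Cc3ccccc3)C[C@H]2[C@@H]1c1ccc(F)cc1)c1cc(C(F)(F)F)cc(C(F)(F)F)c1` is not yet measured. It differs from compound 1 in one place: benzyl in place of hydrogen on an amide-type nitrogen in a ring. The change puts a benzyl on the amide-type nitrogen of the five-membered ring in the fused system, where compound 1 carries only a hydrogen.

Among the measured compounds shown here, no measured pair reports this change, so its size is unknown. The starting point is already at the low end of what the assay shows. A modest step towards a higher number is expected for compound 4, of about a 3.3-fold higher number from compound 1 to compound 4 (0.52 log units; beyond the scatter). Compound 4 is estimated at 0.2 nM, with a range from 0.04 nM to 1 nM.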

Compound 4, half-maximal inhibitory concentration: 2.7 nM
Compound 4: the middle estimate sits 14-fold (1.13 log units) below what was measured; measured number above the stated range.
By their numbers in this assay, from the lowest: compound 1; then compound 3; then compounds 2 and 4 (each within the scatter of the next).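

In this assay, among the compounds shown here, this is the first single-place change that can be read: benzyl in place of hydrogen on the amide-type nitrogen of the five-membered ring gives a 45-fold higher number from compound 1 to compound 4 (1.65 log units; beyond the scatter), a large step. The position is therefore far from indifferent to what it carries, since the entering benzyl costs much of the inhibition seen with the hydrogen, although compound 4 at 2.7 nM still gives a measurable number in this assay. Nothing available accounts for the size of this step, and one pair cannot separate the arrival of the aromatic ring from the departure of the amide hydrogen.

Open, going by these compounds, is whether a small group such as methyl on this nitrogen would stay close to compound 1 or already show much of the step seen with benzyl. Also open, on these data alone, is how cyclohexylmethyl, with no aromatic ring, or a longer chain ending in an amine or a carboxylic acid would read at the same place.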